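Compound 3 to compound 4: chloro to bromo

The source may hold more compounds than are shown below. What is called first, only, known or untested is meant among the compounds shown, and "the series" means these compounds.

Values in a functional assay on MGC-803 cells (Homo sapiens) for inhibition, read by CCK-8 assay, with a stated time of 48 h (a higher number here means a weaker inhibitor, a lower number a stronger inhibitor), are as follows.
Compound 1 `COc1ccc(CN(C(=O)CSC(=S)N2CCN(C(C)=O)CC2)c2cc(OC)c(OC)c(OC)c2)cc1` gives 480 nM
Compound 2 `COc1ccc(CN(C(=O)CSC(=S)N2CCN(C(=O)OC(C)(C)C)CC2)c2cc(OC)c(OC)c(OC)c2)cc1` gives 310 nM
Compound 3 `COc1ccc(CN(C(=O)CSC(=S)N2CCN(C(=O)OC(C)(C)C)CC2)c2ccc(Cl)cc2)cc1` gives > 20000 nM as a limit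

Compound 3 stands at > 20000 nM in this assay and this is a limit of the assay, not a number.

Compound 4 `COc1ccc(CN(C(=O)CSC(=S)N2CCN(C(=O)OC(C)(C)C)CC2)c2ccc(Br)cc2)cc1` carries bromo in place of chloro on an aromatic carbon on a six-membered aromatic ring of carbon only, para to a large group. The closest measured change is an at least 64-fold higher number from compound 2 to compound 3 (1.80 log units; beyond the scatter) for 4-chlorophenyl in place of 3,4,5-trimethoxyphenyl on an amide-type nitrogen, and compound 4 keeps that loss of the 3,4,5-trimethoxyphenyl group. The other measured change, a 1.5-fold lower number from compound 1 to compound 2 (0.19 log units; within the scatter) for tert-butoxy in place of methyl on a carbonyl carbon, concerns a group that compound 3 and compound 4 share. Going by the values given here, no measured pair exchanges one halogen for another. The expected step is a step that the limit leaves unreadable from compound 3 to compound 4 in this assay with no shift beyond the scatter foreseen in either direction. For compound 4 the estimate is 25000 nM with an expected range from 9000 nM to 60000 nM in this series.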

Compound 4, half-maximal inhibitory concentration: > 20000 nM
Compound 4 gave a limit, no number; the forecaster's own chance of this, stated with the estimate: 70%; the middle value does not contradict the limit.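

In this assay, the 4-bromophenyl group on the amide-type nitrogen does not make up for the loss of the 3,4,5-trimethoxyphenyl group, with an at least 64-fold higher number from compound 2 to compound 4 (1.80 log units; beyond the scatter), so the loss seen with 4-chlorophenyl is not confined to one halogen. Compound 4 gives > 20000 nM, which is a limit of the assay and not a number. The change from chloro to bromo itself cannot be read, because compound 3 and compound 4 both stand at the same limit: the limit of > 20000 nM in this assay, at which 2 of the 4 values shown sit.

From the compounds shown here alone, it remains open whether an amine or a carboxylic acid in place of the halogen on this ring would bring a measurable value back into this assay. Also open, going by these compounds, is whether a phenyl group with fewer methoxy groups on that nitrogen would stay close to compound 2 at 310 nM.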